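Pyridin-2-yl at the double-bonded chain carbon: expected step

The compounds below may be only part of what the source reports. "The series", "measured", "known", "first", "only" and "open" are said of these compounds alone.

In a functional assay on HepG2 cells (Homo sapiens) for cytotoxicity, read by MTT assay, with a stated time of 48 h (a lower number here means a stronger inhibitor, a higher number a weaker inhibitor), compound 1 (`O=C1/C(=C\c2ccccc2)S/C(=N/c2ccccc2)N1Cc1ccncc1`) gives 25200 nM. Compound 2 (`COc1ccc(OC)c(/C=C2/S/C(=N/c3ccccc3)N(Cc3ccncc3)C2=O)c1`) gives 35800 nM, within the scatter of compound 1, so the two numbers available do not separate them.

Compound 3 (`O=C1/C(=C\c2ccccn2)S/C(=N/c2ccccc2)N1Cc1ccncc1`) is still unmeasured. Its difference from compound 2 is pyridin-2-yl in place of 2,5-dimethoxyphenyl on a double-bonded chain carbon bound to a double-bonded ring carbon.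

Among the measured compounds shown here, only one measured step bears on this place: a 1.4-fold higher number from compound 1 to compound 2 (0.15 log units; within the scatter). For the measured compounds named here, no measured compound carries pyridin-2-yl, so the reading is indirect, and no step beyond the scatter is expected. The estimated step is a 1.3-fold lower number from compound 2 to compound 3 (0.11 log units; within the scatter). For compound 3 the expected value is 28000 nM, with an estimated range of 12000 nM to 60000 nM.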

Compound 3, half-maximal inhibitory concentration: 31000 nM
Estimate against measurement, compound 3: 1.1-fold (0.04 log units) below; low and high end bracket the measured number.
By their numbers in this assay, from the lowest: compounds 1, 3 and 2 (each within the scatter of the next).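

In this assay, a pyridin-2-yl ring, with its one hetero atom, enters on the double-bonded chain carbon bound to a double-bonded ring carbon, and the reading is a 1.2-fold lower number from compound 2 to compound 3 (0.06 log units; within the scatter), and a 1.2-fold higher number from compound 1 to compound 3 (0.09 log units; within the scatter). Phenyl, 2,5-dimethoxyphenyl and pyridin-2-yl therefore cannot be separated at this place in this assay, so a hetero atom in the ring adds no readable step to what the methoxy-bearing ring had already shown. No measurement is available to explain this flat reading.

Going by these compounds, whether an amine or a carboxylic acid at this place, in place of a six-membered aromatic ring, would give a step beyond the scatter remains open. On these data alone, whether these three groups also go unseparated in other cell types is equally open.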